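A few compounds are considered here, and "the series" means these few. Any claim that something is new, unique, unknown or untested is made for them only; others in the source may bear on it.

Measured compounds in a functional assay on L02 cells (Homo sapiens) for inhibition, read by Griess assay, with stated times of 1 h and 24 h; a higher number here means a weaker inhibitor, a lower number a stronger inhibitor:

Compound 1, `CCCc1nn(C)c2c(NC3CC3)nc(/C=C/c3ccc[n+]([O-])c3)nc12`, compound 1 gives 580000 nM.
Compound 2, `CCCc1nn(C)c2c(NC(C)C)nc(/C=C/c3ccc[n+]([O-])c3)nc12`, compound 2 gives 324000 nM.
Compound 3, `CCCc1nn(C)c2c(NC3CC3)nc(CCc3cccnc3)nc12`, compound 3 gives 564000 nM.

All three numbers lie close together. Compound 1 and compound 2 share a core and differ in one place: isopropyl in place of cyclopropyl on a nitrogen on an aromatic ring. This change gave a 1.8-fold lower number from compound 1 to compound 2 (0.25 log units; within the scatter), a step too small to be read as a real difference. Compound 3 carries a different core from compound 1; how the two cores differ is not broken down here. Its value sits next to that of compound 1, and both are within the scatter of each other, so nothing can be said about their order.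

Compound 4, `CCCc1nn(C)c2c(NC(C)C)nc(CCc3cccnc3)nc12`, has not yet been measured in this assay. It relates to compound 3 as compound 2 relates to compound 1, by the same change: isopropyl in place of cyclopropyl on a nitrogen on an aromatic ring. The place is described in the same words for both pairs, so this counts as the same change made on a second core. On that basis the step from compound 3 to compound 4 is expected to be about the size seen from compound 1 to compound 2, that is within the scatter, giving an expected 1.7-fold lower number from compound 3 to compound 4 (0.23 log units; within the scatter). The expectation rests only on that one earlier pair, which gave a 1.8-fold lower number from compound 1 to compound 2 (0.25 log units; within the scatter), and nothing else in the set tests it. Compound 4 is therefore estimated at 330000 nM, most likely between 150000 nM and 700000 nM.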

Compound 4, half-maximal inhibitory concentration: 514000 nM
For compound 4 the middle estimate is 1.6-fold (0.19 log units) below the measured one; the range from low to high includes it.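

In this assay, among these compounds, putting isopropyl in place of cyclopropyl on a nitrogen on an aromatic ring gave a 1.1-fold lower number from compound 3 to compound 4 (0.04 log units; within the scatter), so on this second core too the change produced no step that can be read as a real difference. Set beside the step on the first core, the new step shows no sign that the change behaves differently from one core to the other: the same change on two cores in this assay, a 1.8-fold lower number (0.25 log units; within the scatter) from compound 1 to compound 2 and a 1.1-fold lower number (0.04 log units; within the scatter) from compound 3 to compound 4, 1.6-fold (0.21 log units) apart, within the scatter of two such steps. This shows only that cyclopropylamino and isopropylamino could not be told apart on either of these two cores; it does not show that the change has a real effect of any size, and with both steps inside the scatter, the agreement between them is a weak test of transfer that says nothing about any further core.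

The compounds shown leave open whether any group on that nitrogen other than these two, such as a longer chain, a benzyl group or a chain ending in a carboxylic acid, would move the number beyond the scatter. They also leave open whether replacing the propyl chain on the shared core with, for example, an amine would do so, and whether the same swap would then still make as little difference.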